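The compounds below may be only part of what the source reports. "The series", "measured", "known", "first", "only" and "open" are said of these compounds alone.

Two compounds of one series have been run in a functional assay on NCI-H460 cells (Homo sapiens) for inhibition, read by sulforhodamine B assay, with a stated time of 48 h; a lower number here means a stronger inhibitor of growth, a higher number a weaker inhibitor of growth. Compound 1 `O=C(Nc1cccc(-n2cc(-c3ccncc3)c(-c3ccc(Cl)c(O)c3)n2)c1)Nc1cccc(C(F)(F)F)c1` gives 1180 nM in this assay. Compound 2 `COc1cc(-c2nn(-c3cccc(NC(=O)Nc4cc(C(F)(F)F)cc(C(F)(F)F)c4)c3)cc2-c2ccncc2)ccc1Cl` gives 558 nM in this assay, the lower of the two numbers, and its gap to compound 1 lies beyond the usual scatter. Going by the values given here, compound 2 and compound 1 differ in two places at once, so no single step between them can be read off.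

Compound 3 `O=C(Nc1cccc(-n2cc(-c3ccncc3)c(-c3ccc(Cl)c(O)c3)n2)c1)Nc1cc(C(F)(F)F)cc(C(F)(F)F)c1` has not yet been measured. It differs from compound 2 in one place: hydrogen in place of methyl on an oxygen on an aromatic ring, methoxy to hydroxy. Among the compounds with values here, no measured pair shows this change on its own. Compound 3 is expected to sit close to compound 2, with a step from compound 2 to compound 3 of a 1.4-fold higher number from compound 2 to compound 3 (0.16 log units; within the scatter) that need not exceed the scatter. In this assay compound 3 is estimated at 800 nM, between 350 nM and 1800 nM.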

Compound 3, concentration for 50% growth inhibition: 413 nM
Estimate against measurement, compound 3: 1.9-fold (0.29 log units) above; the measured number falls inside the stated range.
By their numbers in this assay, from the lowest: compounds 3 and 2 (each within the scatter of the next); then compound 1.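

In this assay, the change from methoxy to hydroxy on the oxygen on the aromatic ring gives a 1.4-fold lower number from compound 2 to compound 3 (0.13 log units; within the scatter), which lies within the scatter, so here the methyl on that oxygen can be replaced by hydrogen with no discernible change in growth inhibition. Going by these compounds alone, compound 3 also provides the first single-place step beyond the scatter: trifluoromethyl in place of hydrogen on an aromatic carbon gives a 2.9-fold lower number from compound 1 to compound 3 (0.46 log units; beyond the scatter), a modest gain. Nothing available explains either step.

Each change is seen only once, so the compounds shown leave open whether either step would hold on a different background. They also leave open how a longer chain such as ethoxy, or an amine in place of the hydroxy group, would compare.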